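Chain Lengthening Toward Compound 4: An Expected Loss

The source may report more compounds than this note shows. Statements on the series, on what has been measured and on what is new or still open speak of the compounds shown alone.

Measured so far:
compound 1, `C#CCN(C)CCCCCOc1ccc2c(c1)CCC2=O`: 31%
compound 2, `C#CCN(C)CCCCCCOc1ccc2c(c1)CCC2=O`: 4.42%
compound 3, `C#CCN(C)CCCCCOc1ccc2c(c1)CCCC2=O`: 26.1%

In an ADME assay on BTI cells for inhibition of Amine oxidase [flavin-containing] A (Homo sapiens), read by fluorescence and Amplex Red, with a stated time of 15 min, tested at 100 uM (on this read-out lower numbers stand for less inhibition and higher numbers for more inhibition at the one concentration tested (going by the name of the read-out)), compound 1 gives 31% and compound 2 gives 4.42%. The change between them, ((methyl(propargyl)amino)methyl in place of methyl(propargyl)amino on a saturated chain carbon, five bonds along the chain from an oxygen on an aromatic ring), brought a step of a number 26.6 percentage points lower from compound 1 to compound 2 (beyond the scatter). The core of compound 3 differs from that of compound 1 in a way that is not broken down here; compound 3 gives 26.1%, a value within the scatter of compound 1. Compound 4, `C#CCN(C)CCCCCCOc1ccc2c(c1)CCCC2=O`, is not yet measured; it carries the same change as before, ((methyl(propargyl)amino)methyl in place of methyl(propargyl)amino on a saturated chain carbon, five bonds along the chain from an oxygen on an aromatic ring). Among the compounds with values here, since the one earlier instance of this change is a number 26.6 percentage points lower from compound 1 to compound 2 (beyond the scatter), a step of similar size, a number 21.1 percentage points lower from compound 3 to compound 4 (beyond the scatter), is expected from compound 3 to compound 4. Compound 4 is therefore estimated at 5%, expected to lie between 0% and 18%.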

Compound 4, a percentage reported as inhibition, at one concentration (the size of the read-out at that concentration, not a potency): 25%
Estimate against measurement, compound 4: 20 percentage points below; measured number outside the range, above it.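

In this assay, putting (methyl(propargyl)amino)methyl in place of methyl(propargyl)amino gave a step of a number 1.1 percentage points lower from compound 3 to compound 4 (within the scatter), so the change did not carry over from one core to the other with the same size: the same change on two cores in this assay, a number 26.6 percentage points lower (beyond the scatter) from compound 1 to compound 2 and a number 1.1 percentage points lower (within the scatter) from compound 3 to compound 4, 25.5 percentage points apart, beyond the scatter of two such steps

In these two pairs, then, the outcome of the change depends on the core, and a step seen on one core is no safe guide to the other. The data do not show which feature of the core matters, and two pairs give no general rule for the series.

From the compounds shown here alone, it remains open how a longer chain would behave on each core. Going by these compounds, it also remains open whether a dimethylamino group in place of methyl(propargyl)amino would show the same dependence on the core.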